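The source may hold more compounds than are shown below. What is called first, only, known or untested is meant among the compounds shown, and "the series" means these compounds.

Measured so far in a functional assay on HT-29 cells (Homo sapiens) for antiproliferative activity, read by sulforhodamine B assay, with a stated time of 48 h; a higher number here means a weaker inhibitor, a lower number a stronger inhibitor:
- compound 1 `Cc1cccc(NS(=O)(=O)c2ccc(N3CCNC3=O)cc2)c1`: 110 nM
- compound 2 `Cc1ccc(NS(=O)(=O)c2ccc(N3CCNC3=O)cc2)cc1C`: 230 nM
- compound 3 `O=C1NCCN1c1ccc(S(=O)(=O)Nc2ccccc2)cc1`: 280 nM

Compound 1 carries the lowest number of the three; its nearest neighbour is compound 2, a 2.1-fold higher number from compound 1 to compound 2 (0.32 log units; beyond the scatter), and the furthest is compound 3, a 2.5-fold higher number from compound 1 to compound 3 (0.41 log units; beyond the scatter). Compounds 2 and 3 sit within the scatter of each other, a 1.2-fold higher number from compound 2 to compound 3 (0.09 log units; within the scatter).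

Compound 4 `O=C1NCCN1c1ccc(S(=O)(=O)Nc2ccc(Br)cc2)cc1` is not yet measured. It differs from compound 1 in one place: 4-bromophenyl in place of 3-methylphenyl on a sulfonamide nitrogen.

The bearing steps are the two that change the aryl group on the sulfonamide nitrogen. Taking the methyl off compound 1 to give compound 3 costs a 2.5-fold higher number from compound 1 to compound 3 (0.41 log units; beyond the scatter); adding a second methyl to give compound 2 costs a 2.1-fold higher number from compound 1 to compound 2 (0.32 log units; beyond the scatter). Both are modest and both point the same way, so every change so far away from the 3-methylphenyl of compound 1 has raised the number by a modest amount. Among the measured compounds shown here, no measured compound carries a bromine, so the size of this particular exchange is not fixed by the data.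

Given that, compound 4 is expected to come out at about 250 nM, within 110 nM to 600 nM, a modest expected weakening of a 2.3-fold higher number from compound 1 to compound 4 (0.36 log units; beyond the scatter) in this assay, in line with compound 3 at 280 nM.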

Compound 4, half-maximal inhibitory concentration: 300 nM
Beside the measured number, compound 4's estimate is 1.2-fold (0.08 log units) below it; low and high end bracket the measured number.
By their numbers in this assay, from the lowest: compound 1; then compounds 2, 3 and 4 (each within the scatter of the next).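

In this assay, 4-bromophenyl in place of 3-methylphenyl on the sulfonamide nitrogen gives a 2.7-fold higher number from compound 1 to compound 4 (0.44 log units; beyond the scatter) and is a modest step, so compound 1 keeps the lowest number against a third aryl group, this time one carrying a halogen rather than a methyl. The change from phenyl to 4-bromophenyl gives a 1.1-fold higher number from compound 3 to compound 4 (0.03 log units; within the scatter) and the change from 3,4-dimethylphenyl to 4-bromophenyl gives a 1.3-fold higher number from compound 2 to compound 4 (0.12 log units; within the scatter), both within the scatter, so compounds 2, 3 and 4 form one group that the aryl changes shown so far do not separate. Nothing measured alongside these numbers accounts for the edge of the 3-methylphenyl group or for the lack of any separation within that group.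

Open, going by these compounds, is whether a methoxy group, an amine or a carboxylic acid on this aryl ring would fall with compounds 2, 3 and 4 or reach the number of compound 1. Also open, on these data alone, is how any of these aryl groups would read with a longer chain on the nitrogen of the shared core.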